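The source may report more compounds than this note shows. Statements on the series, on what has been measured and on what is new or still open speak of the compounds shown alone.

Measured so far in a functional assay on HeLa cells (Homo sapiens) for inhibition; on this read-out lower numbers stand for stronger inhibition and higher numbers for weaker inhibition:

Compound 1 `CCN(C(=O)CC(CC(=O)NCCN1CCCC1)c1ccc(Cl)cc1)C1Cc2ccccc2C1` gives 36400 nM.
Compound 2 `CN(C(=O)CC(CC(=O)NCCN1CCCC1)c1ccccc1)C1Cc2ccccc2C1` gives only a limit of the assay, > 100000 nM.
Compound 3 `CCN(CC)CCNC(=O)CC(CC(=O)N(C)C1Cc2ccccc2C1)c1ccccc1` likewise gives only a limit of the assay, > 100000 nM.

Compound 4 `CCN(CC)CCNC(=O)CC(CC(=O)N(CC)C1Cc2ccccc2C1)c1ccc(Cl)cc1` has not been measured in this assay. It is related to compound 1 by diethylamino in place of pyrrolidin-1-yl on a saturated chain carbon, two bonds along the chain from an amide-type nitrogen. The same change, in the same place word for word, is made from compound 2 to compound 3: diethylamino in place of pyrrolidin-1-yl on a saturated chain carbon, two bonds along the chain from an amide-type nitrogen. The difference between the two cores, that of compound 1 and that of compound 2, is not broken down here.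

The measured occurrence of the change gives no readable size: a step that the two limits leave unreadable from compound 2 to compound 3. Going by the values given here, both ends of that step sit at the limit of > 100000 nM in this assay, at which 2 of the 3 values shown sit, so it shows neither direction nor magnitude, only that neither compound 2 nor compound 3 reaches a number within the range of this assay.

For compound 1 to compound 4 the expectation therefore rests on compound 1 alone, with the change from pyrrolidin-1-yl to diethylamino taken as roughly neutral for want of any readable precedent; the step is expected to be about a 1.1-fold higher number from compound 1 to compound 4 (0.04 log units; within the scatter). Compound 4 is accordingly estimated at 40000 nM in this assay, with a range from 15000 nM to 100000 nM, and a real chance that, like compound 2 and compound 3, only a limit is reported.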

Compound 4, half-maximal inhibitory concentration: 24300 nM
Compound 4: middle estimate off by 1.6-fold (0.22 log units), on the high side, within the range that was stated.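

In this assay, on the core of compound 1, diethylamino in place of pyrrolidin-1-yl gives a 1.5-fold lower number from compound 1 to compound 4 (0.18 log units; within the scatter), so on this core, opening the five-membered ring into the diethylamino group leaves the result within the scatter. Compound 2 and compound 3 each give only a limit of the assay, so the same change on their core cannot be read: the limit of > 100000 nM in this assay, at which 2 of the 4 values shown sit. The series therefore holds a single readable occurrence of this change, which supports treating it as without a readable effect on the core of compound 1 but does not show that it carries over to another core, as no second size exists to set beside the first.

From the compounds shown here alone, it remains open whether another amine in the same place, such as piperidin-1-yl, morpholin-4-yl or dimethylamino, would also stay within the scatter of compound 1, and whether a longer chain between the amide-type nitrogen and the amine would do so. Going by these compounds, the difference between the core of compound 1 and the core of compound 2 is also not broken down, so it remains open which part of it separates a readable number from a limit.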